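A few compounds are considered here, and "the series" means these few. Any claim that something is new, unique, unknown or untested is made for them only; others in the source may bear on it.

Working notes on the series. Compound 1 `CCOC(=O)c1cnn(CC(C)O)c1NC(=O)NCc1ccccc1` and compound 2 `CCOC(=O)c1cnn(CC(O)CC)c1NC(=O)Nc1cccc2ccccc12` share the core and differ on the urea side and on the hydroxyalkyl chain. In a functional assay on cells (Neutrophil, Homo sapiens) for inhibition, with a stated time of 10 min (on this read-out lower numbers stand for stronger inhibition and higher numbers for weaker inhibition), compound 1 gives 15 nM; in this assay compound 2 gives 12 nM. Compound 1 has the higher of the two numbers, but the gap to compound 2 lies within the scatter, so the two are not separated. Compound 3 `CCOC(=O)c1cnn(CC(C)O)c1NC(=O)NC(C)C` differs from compound 1 by isopropyl in place of benzyl on an amide-type nitrogen. For the measured compounds named here, no measured step of this kind exists, so the size of the effect rests on the change alone. An aromatic ring leaves without replacement; a step toward weaker inhibition beyond the scatter is expected, as a 4.0-fold higher number from compound 1 to compound 3 (0.60 log units; beyond the scatter). Compound 3 is expected at 60 nM, with a range from 15 nM to 300 nM.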

Compound 3, half-maximal inhibitory concentration: 90 nM
Beside the measured number, compound 3's estimate is 1.5-fold (0.18 log units) below it, and the stated range covers the measured number.
By their numbers in this assay, from the lowest: compounds 2 and 1 (each within the scatter of the next); then compound 3.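

In this assay, isopropyl in place of benzyl on an amide-type nitrogen gives a 6.0-fold higher number from compound 1 to compound 3 (0.78 log units; beyond the scatter). For the compounds shown here, this is the first single-place step, and it shows that inhibition at this position responds to the group carried on the urea side. The change removes the aromatic ring and leaves the rest of compound 1 unchanged, but no measurement shown gives a reason for the step. The compounds shown leave open whether the aromatic ring itself or the number of carbons in the group matters here. A cyclohexylmethyl group on this nitrogen would separate the two.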